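A Flexible Amine Replaces the Piperazine on a Weak Inhibitor

The source may report more compounds than this note shows. Statements on the series, on what has been measured and on what is new or still open speak of the compounds shown alone.

The series shares one core. Compound 1 `CCN1CCN(c2nc(Oc3ccc4ccc(=O)[nH]c4c3)c3sccc3n2)CC1` carries an ethylpiperazine directly on that core, and in a functional assay on PC-9 cells (Homo sapiens) for antiproliferative activity, read by MTT assay, with a stated time of 72 h (a higher number here means a weaker inhibitor, a lower number a stronger inhibitor), compound 1 has "not determined" (no result reported). Compound 2 `CN1CCN(c2ccc(Nc3nc(Oc4ccc5ccc(=O)[nH]c5c4)c4sccc4n3)cc2)CC1` instead bears an anilino group with a methylpiperazine, and in this assay compound 2 gives 5780 nM. Compound 3 `CN1CCN(c2ccc(Nc3nc(Oc4ccc5ccc(=O)[nH]c5c4)c4sccc4n3)cc2F)CC1` adds a fluoro group to that aniline. In this assay compound 3 reaches only > 50000 nM, which is a limit of the assay rather than a number. The step of an at least 8.6-fold higher number from compound 2 to compound 3 (0.93 log units; beyond the scatter) therefore rests on a limit, and compound 3 accounts for (the limit of > 50000 nM in this assay, at which 1 of the 3 values shown sits); it stands at the weak end of what is shown.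

Compound 4 `CN(C)CCNc1ccc(Nc2nc(Oc3ccc4ccc(=O)[nH]c4c3)c3sccc3n2)cc1F` keeps the fluoro group of compound 3 and changes the amine: (2-(dimethylamino)ethyl)amino in place of 4-methylpiperazin-1-yl on an aromatic carbon. Going by the values given here, no measured step bears on this swap; the one measured step, an at least 8.6-fold higher number from compound 2 to compound 3 (0.93 log units; beyond the scatter), concerns the fluoro group, which compound 4 retains. With compound 3 at a limit, the direction and size of the change in this assay cannot be read from the shown compounds, and no step beyond the scatter is expected in either direction. Compound 4 is therefore estimated at 40000 nM, within 8000 nM to 200000 nM. The step of an at least 1.2-fold lower number from compound 3 to compound 4 (0.09 log units; that floor lies within the scatter) is expected to leave compound 4 near the limit.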

Compound 4, half-maximal inhibitory concentration: 16000 nM
The estimate for compound 4 lay 2.5-fold (0.40 log units) above the measured number; the range from low to high includes it.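

With the fluoro group held fixed, replacing 4-methylpiperazin-1-yl with (2-(dimethylamino)ethyl)amino gives an at least 3.1-fold lower number from compound 3 to compound 4 (0.49 log units; beyond the scatter) in this assay. This shows that the amine, para to a large group and ortho to a fluoro group, is a place where a change moves the read-out, whereas the earlier step concerned only the fluoro group itself. The change removes the six-membered ring, adds a hydrogen-bond donor and leaves one heavy atom fewer, and this single step cannot separate those differences; its size is only a floor, since compound 3 stands at a limit and not at a number: the limit of > 50000 nM in this assay, at which 1 of the 4 values shown sits.

The compounds shown leave open whether the same amine swap would have a similar effect on the aniline without the fluoro group, as no pair isolates that change. They also leave open how the read-out would respond to a longer chain such as (3-(dimethylamino)propyl)amino, to a morpholine at this position, or to a secondary amine in place of the terminal dimethylamino group.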